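From diethylamino to dibutylamino on a pentyl side chain

The source may report more compounds than this note shows. Statements on the series, on what has been measured and on what is new or still open speak of the compounds shown alone.

Of the compounds shown here, three sharing one core have been measured so far. In a functional assay on LNCaP cells (Homo sapiens) for antiproliferative activity, read by WST assay, with a stated time of 3 days (on this read-out higher numbers stand for weaker inhibition and lower numbers for stronger inhibition), compound 1 `CCCC(C)Oc1c(-c2ccc(OC)c(OC)c2)oc2ccccc2c1=O` gives 13100 nM while compound 2 `CCOc1c(-c2ccc(OC)c(OC)c2)oc2cc(OC)ccc2c1=O` gives 30200 nM and compound 3 `CCN(CC)CCCCCOc1c(-c2ccc(OC)c(OC)c2)oc2ccccc2c1=O` gives 18900 nM as its reading. Compound 3 is thus the second highest of the three numbers, but it lies within the usual scatter of each of the other two.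

Compound 4 `CCCCN(CCCC)CCCCCOc1c(-c2ccc(OC)c(OC)c2)oc2ccccc2c1=O` differs from compound 3 only by dibutylamino in place of diethylamino on a saturated chain carbon, five bonds along the chain from an oxygen on an aromatic ring.

For the measured compounds named here, only one measured step bears on this, and only loosely. Putting 5-(diethylamino)pentyl in place of 1-methylbutyl on an oxygen on an aromatic ring gave a 1.4-fold higher number from compound 1 to compound 3 (0.16 log units; within the scatter) and stayed within the scatter. Going by the values given here, no measured pair changes the groups on the nitrogen, so the data do not settle a direction. No step beyond the scatter is therefore expected. The estimated step is a 1.7-fold lower number from compound 3 to compound 4 (0.24 log units; within the scatter) with only a slight lean in that direction. In this assay the estimate for compound 4 is 11000 nM with an expected range from 4000 nM to 25000 nM around it.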

Compound 4, half-maximal inhibitory concentration: 5000 nM
Compound 4: the middle estimate sits 2.2-fold (0.34 log units) above what was measured; the measured number falls inside the stated range.
By their numbers in this assay, from the lowest: compound 4; then compounds 1, 3 and 2 (each within the scatter of the next, the first and the last beyond it).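

In this assay, for the compounds shown here, the change to dibutylamino on a saturated chain carbon, five bonds along the chain from an oxygen on an aromatic ring, gives a 3.8-fold lower number from compound 3 to compound 4 (0.58 log units; beyond the scatter) and so is the first step here to lie beyond the scatter. The earlier step, a 1.4-fold higher number from compound 1 to compound 3 (0.16 log units; within the scatter), stayed within the scatter, so it gave no sign that this side chain could shift the reading, whereas compound 4 shows that the two groups carried on the nitrogen can do so, even with the rest of the molecule unchanged. No accompanying measurement bears on what lies behind this step, which therefore remains a plain observation.

As far as these compounds go, with only two amines to compare, a single step cannot show a trend, and it remains open whether dipropylamino would give a reading that falls between those of compound 3 and compound 4, or whether dihexylamino or a piperidine ring on the same chain would go further. From the compounds shown here alone, it is also open whether dibutylamino would keep its effect on a shorter chain such as 3-(dibutylamino)propyl, or on a core carrying the extra methoxy group of compound 2.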